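A Longer Side Chain on Compound 1

The source may hold more compounds than are shown below. What is called first, only, known or untested is meant among the compounds shown, and "the series" means these compounds.

- compound 1 `C=C(C)CC[C@]1(C)C2=CCC[C@](C)(C[C@H](O)c3ccoc3)[C@H]2CC[C@H]1C`: 34000 nM
- compound 2 `C=C(C)CC[C@]1(C)C2=CCC[C@](C)(C[C@@H](O)c3ccoc3)[C@H]2CC[C@H]1C`: 34000 nM

In a functional assay on A549 cells (Homo sapiens) for antiproliferative activity, read by XTT assay, with a stated time of 72 h (a lower number here means a stronger inhibitor, a higher number a weaker inhibitor), compound 1 gives 34000 nM, level with compound 2 at 34000 nM. Compound 3 `C=C(C)CCC[C@]1(C)C2=CCC[C@](C)(C[C@H](O)c3ccoc3)[C@H]2CC[C@H]1C` keeps the core of compound 1 and changes one chain end: 2-methylprop-2-en-1-yl in place of 1-methylethenyl on a saturated chain carbon, two bonds along the chain from a saturated ring carbon. The new group sits on a saturated chain carbon, two bonds along the chain from a saturated ring carbon. For the measured compounds named here, the only measured step is no change at the digits printed from compound 1 to compound 2 (within the scatter), and it is an indirect guide here, given (the fact that compounds 1 and 2 differ only in the configuration as drawn). Going by the values given here, no measured step tests this chain change, so no shift beyond the scatter, in either direction, is expected in this assay. The expected step is a 1.1-fold lower number from compound 1 to compound 3 (0.05 log units; within the scatter). For compound 3 the estimate is 30000 nM, with an expected range of 14000 nM to 60000 nM.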

Compound 3, half-maximal inhibitory concentration: 66000 nM
For compound 3 the middle estimate is 2.2-fold (0.34 log units) below the measured one, and the stated range ends below it.
By their numbers in this assay, from the lowest: compounds 1, 2 and 3 (each within the scatter of the next).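

In this assay, 2-methylprop-2-en-1-yl in place of 1-methylethenyl gives a 1.9-fold higher number from compound 1 to compound 3 (0.29 log units; within the scatter), so this chain end takes the change without a shift that stands clear of the scatter. For the compounds shown here, the earlier pair spoke only to configuration as drawn, and this is the first look at the chain end itself. Nothing at hand gives a reason for this result. As far as these compounds go, whether a longer chain such as 3-methylbut-3-en-1-yl, or an amine or a carboxylic acid at this chain end, would behave the same stays open. So does the outcome of the same chain change on compound 2.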